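A few compounds are considered here, and "the series" means these few. Any claim that something is new, unique, unknown or untested is made for them only; others in the source may bear on it.

compound 1 `COc1ccc(C(O)C2OC(=O)c3c(OC)cc(OC)cc32)cc1` gives > 10000 nM (a limit)
compound 2 `COCCOc1ccc(C(O)C2OC(=O)c3c(OC)cc(OC)cc32)cc1` gives > 10000 nM (a limit)
compound 3 `COCCCOc1ccc(C(O)C2OC(=O)c3c(OC)cc(OC)cc32)cc1` gives 1260 nM (a measured number)

Within the data shown here, compound 3 holds the only real number of this set in a functional assay on RAW264.7 cells (Mus musculus) for inhibition, read by Griess assay, with stated times of 1 h and 24 h (on this read-out lower numbers stand for stronger inhibition and higher numbers for weaker inhibition), and so serves as the reference. Compound 1 and compound 2 are known only through the limit of > 10000 nM in this assay, at which 2 of the 3 values shown sit, and each of these is a limit.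

Compound 4 `C=CCCOc1ccc(C(O)C2OC(=O)c3c(OC)cc(OC)cc32)cc1` keeps the shared core and changes only the end of the chain: vinyl in place of methoxymethyl on a saturated chain carbon, two bonds along the chain from an oxygen on an aromatic ring with 3-methoxypropoxy replaced by (but-3-en-1-yl)oxy. The closest measured change sits at the same place, where an at least 7.9-fold lower number from compound 2 to compound 3 (0.89 log units; beyond the scatter) came with methoxymethyl in place of methoxy. Similarly, an at least 7.9-fold lower number from compound 1 to compound 3 (0.89 log units; beyond the scatter) came with 2-methoxyethyl in place of hydrogen, whereas a step that the two limits leave unreadable from compound 1 to compound 2 tells nothing about size.

Among the measured compounds shown here, no measured compound tests the loss of the chain oxygen. Compound 4 keeps a chain at that place, so most of the gain seen in an at least 7.9-fold lower number from compound 2 to compound 3 (0.89 log units; beyond the scatter) is expected to survive. The expected change is a 2.0-fold higher number from compound 3 to compound 4 (0.30 log units; within the scatter) and it is a small one. Compound 4 is estimated at 2500 nM with an expected range from 700 nM to 9000 nM in this assay as well.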

Compound 4, half-maximal inhibitory concentration: 1330 nM
Compound 4: the middle estimate sits 1.9-fold (0.27 log units) above what was measured; measured number inside the range.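

In this assay, the oxygen inside the chain proves dispensable at this position, since vinyl in place of methoxymethyl gives a 1.1-fold higher number from compound 3 to compound 4 (0.02 log units; within the scatter), so compound 3 and compound 4 cannot be told apart. The (but-3-en-1-yl)oxy chain also stands well clear of the two weakest entries, with an at least 7.5-fold lower number from compound 2 to compound 4 (0.87 log units; beyond the scatter) and an at least 7.5-fold lower number from compound 1 to compound 4 (0.87 log units; beyond the scatter), which shows that the gain seen with 3-methoxypropoxy does not depend on a methoxy end. These two steps have only one bound, as compound 1 and compound 2 are known only as limits, not as numbers: the limit of > 10000 nM in this assay, at which 2 of the 4 values shown sit.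

How far the chain can grow remains open, since a longer chain such as hexyloxy does not appear among these compounds. Also open, on these data alone, is how an amine or a carboxylic acid at the chain end would compare with vinyl.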